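The compounds below may be only part of what the source reports. "The series", "measured", "known", "first", "only" and "open" are said of these compounds alone.

Measured so far:
Compound 1 `CCc1cc(C/N=c2\c(O)c(O)\c2=N/C(C)(C)C)ccc1C#N` in a functional assay for inhibition, with Rattus norvegicus as the target; on this read-out lower numbers stand for stronger inhibition and higher numbers for weaker inhibition: 6100 nM.
Compound 2 `C/N=c1\c(O)c(O)\c1=N/Cc1ccc(C#N)cc1` in this assay: > 30000 nM, a limit of the assay and not a number.
Compound 3 `N#Cc1ccc(CNc2c(N)c(=O)c2=O)cc1` in this assay: > 30000 nM, also a limit of the assay.

Compound 2 therefore stands at the limit of > 30000 nM in this assay, at which 2 of the 3 values shown sit, so only an upper bound on its potency is known. Compound 4 `CC(C)(C)/N=c1\c(O)c(O)\c1=N/Cc1ccc(C#N)cc1` differs from compound 2 by tert-butyl in place of methyl on a double-bonded nitrogen. For the measured compounds named here, no pair of measured compounds that differ in one place is available, so the size of this step cannot be read from a measured pair. Compound 1, which also carries tert-butyl on that nitrogen, gives a number in this assay, 6100 nM. On that basis the step from compound 2 to compound 4 is expected to go toward stronger inhibition, beyond the scatter, an at least 3.0-fold lower number from compound 2 to compound 4 (0.47 log units; beyond the scatter). Compound 4 is estimated at 10000 nM, with a range of 3000 nM to 30000 nM.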

Compound 4, half-maximal inhibitory concentration: 270 nM
Compound 4: middle estimate off by 37-fold (1.57 log units), on the high side; measured number below the stated range.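

With tert-butyl in place of methyl on the double-bonded nitrogen, the series now shows an at least 110-fold lower number from compound 2 to compound 4 (2.04 log units; beyond the scatter), so inhibition depends strongly on the group at this position. Compound 2 remains only a limit of the assay, not a number: the limit of > 30000 nM in this assay, at which 2 of the 4 values shown sit. On the aromatic carbon, hydrogen in place of ethyl gives a 23-fold lower number from compound 1 to compound 4 (1.35 log units; beyond the scatter), so ethyl there goes with weaker inhibition.

Isopropyl or a longer chain on that nitrogen remains open, since only methyl and tert-butyl can be compared there. Also open, on these data alone, is whether methyl or fluorine on the aromatic carbon behaves like ethyl.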